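A few compounds are considered here, and "the series" means these few. Any claim that something is new, unique, unknown or untested is made for them only; others in the source may bear on it.

For the measured compounds named here, in a functional assay on MCF7 cells (Homo sapiens) for antiproliferative activity, read by MTT assay, with a stated time of 72 h (on this read-out higher numbers stand for weaker inhibition and lower numbers for stronger inhibition), compound 2 `COc1ccc(-c2ccc3ncn(-c4cc(OC)c(OC)c(OC)c4)c3c2)cc1` gives 210 nM, the lowest of the three numbers so far. Compound 1 `COc1cc(-n2cnc3ccc(-c4ccc(C(F)(F)F)cc4)cc32)cc(OC)c1OC` gives 760 nM in this assay, and compound 3 `COc1cc(-n2cnc3ccc(-c4ccccc4)cc32)cc(OC)c1OC` gives 2290 nM. The measured steps are all exchanges on the aromatic carbon of the pendant ring: a 3.6-fold lower number from compound 1 to compound 2 (0.56 log units; beyond the scatter), a 3.0-fold higher number from compound 1 to compound 3 (0.48 log units; beyond the scatter) and an 11-fold higher number from compound 2 to compound 3 (1.04 log units; beyond the scatter). Compound 4 `CCOc1ccc(-c2ccc3ncn(-c4cc(OC)c(OC)c(OC)c4)c3c2)cc1` differs from compound 2 by methyl in place of hydrogen on a saturated chain carbon bound to an oxygen on an aromatic ring. Going by the values given here, no measured step touches that chain carbon; the steps already seen show only that a methoxy at this position of the pendant ring is worth far more than hydrogen or trifluoromethyl, and they say nothing about lengthening the chain beyond methyl. Among the compounds with values here, with no step bearing directly on the change, compound 4 is expected to land near compound 2, with a step of a 1.4-fold higher number from compound 2 to compound 4 (0.15 log units; within the scatter) that is expected to stay within the scatter. Compound 4 is therefore estimated at 300 nM in this assay, within a range from 110 nM to 850 nM.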

Compound 4, half-maximal inhibitory concentration: 1710 nM
Beside the measured number, compound 4's estimate is 5.7-fold (0.76 log units) below it, outside the stated range (above it).
By their numbers in this assay, from the lowest: compound 2; then compound 1; then compounds 4 and 3 (each within the scatter of the next).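

In this assay, extending the chain by one methyl removes most of the advantage of methoxy on the pendant ring, with an 8.1-fold higher number from compound 2 to compound 4 (0.91 log units; beyond the scatter). Ethoxy and hydrogen on that aromatic carbon cannot be told apart, since the step is a 1.3-fold lower number from compound 3 to compound 4 (0.13 log units; within the scatter), and ethoxy also falls on the weaker side of trifluoromethyl, with a 2.3-fold higher number from compound 1 to compound 4 (0.35 log units; beyond the scatter). The earlier compounds shown here showed methoxy as the best of the groups at this place, and this result shows that its advantage does not carry over to ethoxy, so the saturated chain carbon bound to the oxygen is sensitive to this change.

No evidence is available to explain the size of this loss. Going by these compounds, it remains open how a longer chain such as propoxy, or a hydroxyl or an amine on the same aromatic carbon, would compare with methoxy.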